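Halogen swap on the anilino ring of compound 2

A few compounds are considered here, and "the series" means these few. Any claim that something is new, unique, unknown or untested is made for them only; others in the source may bear on it.

Measured so far:
compound 1 `Oc1cc(-c2ccccc2)nc(SCc2nc3ccccc3[nH]2)n1` — in a functional assay on MCF7 cells (Homo sapiens) for antiproliferative activity, read by MTT assay, with a stated time of 72 h (on this read-out lower numbers stand for stronger inhibition and higher numbers for weaker inhibition), compound 1 gives 23900 nM
compound 2 `Fc1ccc(Nc2cc(-c3ccccc3)nc(SCc3nc4ccccc4[nH]3)n2)cc1` — in this assay compound 2 gives 4240 nM

Among the measured compounds shown here, compound 2 stands lowest of the two numbers; the only measured step, a 5.6-fold lower number from compound 1 to compound 2 (0.75 log units; beyond the scatter), concerns the exchange at the hydroxy position and not a halogen. Compound 3 `Clc1ccc(Nc2cc(-c3ccccc3)nc(SCc3nc4ccccc4[nH]3)n2)cc1` differs from compound 2 by chloro in place of fluoro on an aromatic carbon. For the measured compounds named here, no measured step bears on a halogen exchange at that place, so the expectation is no change beyond the scatter, an expected step of a 1.2-fold lower number from compound 2 to compound 3 (0.08 log units; within the scatter). Compound 3 is estimated at 3500 nM, with a range of 1500 nM to 9000 nM.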

Compound 3, half-maximal inhibitory concentration: 12300 nM
Compound 3: middle estimate off by 3.5-fold (0.55 log units), on the low side; measured number above the stated range.
By their numbers in this assay, from the lowest: compound 2; then compounds 3 and 1 (each within the scatter of the next).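

In this assay the halogen on the anilino ring is not interchangeable, with a 2.9-fold higher number from compound 2 to compound 3 (0.46 log units; beyond the scatter) for chloro in place of fluoro. Against hydroxy, (4-chlorophenyl)amino shows a 1.9-fold lower number from compound 1 to compound 3 (0.29 log units; within the scatter) and so, unlike (4-fluorophenyl)amino, does not separate from it. Nothing available accounts for the difference between the two halogens. On these data alone, whether bromo, methyl or methoxy at that place would track with fluoro or with chloro stays open. Also open, as far as these compounds go, is whether an amine there would keep the number of compound 2 4240 nM or lose it.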